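Replacing 4-methylphenyl with 2-bromophenyl

This account rests on a few compounds, and the source may have more. Where it says the series, first, only, none or still open, it means among the compounds named here.

Measured in a functional assay for inhibition, with Homo sapiens as the target; on this read-out lower numbers stand for tighter binding and higher numbers for weaker binding:
- compound 1 `O=C(O)CC/C=C\CC1COC(c2ccc(Cl)cc2Cl)OC1c1cccnc1`: 891 nM
- compound 2 `CC(C)(Oc1ccccc1)C1OCC(C/C=C\CCC(=O)O)C(c2cccnc2)O1`: 75.9 nM
- compound 3 `Cc1ccc(OC(C)(C)C2OCC(C/C=C\CCC(=O)O)C(c3cccnc3)O2)cc1`: 631 nM

Compound 3 sits at 631 nM, level with compound 1 at 891 nM once the usual scatter is allowed for. Both numbers stand well above that of compound 2, so compound 3 binds clearly more weakly than compound 2.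

The next compound to be tested is compound 4 `CC(C)(Oc1ccccc1Br)C1OCC(C/C=C\CCC(=O)O)C(c2cccnc2)O1`. It has 2-bromophenyl in place of 4-methylphenyl on an oxygen on a saturated carbon.

Going by the values given here, two measured steps bear on this change. The closer one is an 8.3-fold higher number from compound 2 to compound 3 (0.92 log units; beyond the scatter), where methyl takes the place of hydrogen on an aromatic carbon. The other is a 12-fold lower number from compound 1 to compound 2 (1.07 log units; beyond the scatter), which shows that replacing a whole group on a saturated ring carbon can also move the number a long way. Compound 4 lacks the methyl that separates compound 3 from compound 2, which suggests a move back towards lower numbers. However, no measured compound carries bromine, so the size of that move is uncertain and only part of the gap is assumed to close.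

The expected change is a 3.5-fold lower number from compound 3 to compound 4 (0.54 log units; beyond the scatter). The estimated value for compound 4 is 180 nM, with an expected range from 45 nM to 700 nM.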

Compound 4, dissociation constant: 63.1 nM
For compound 4 the middle estimate is 2.9-fold (0.46 log units) above the measured one, within the range that was stated.
By their numbers in this assay, from the lowest: compounds 4 and 2 (each within the scatter of the next); then compounds 3 and 1 (each within the scatter of the next).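

In this assay, putting 2-bromophenyl in place of 4-methylphenyl on an oxygen on a saturated carbon brings the number down a long way (a 10-fold lower number from compound 3 to compound 4 (1.00 log units; beyond the scatter)), so the higher number that came with methyl does not apply to every substituent on this aromatic ring. When the unsubstituted ring gains a bromine, the number stays level with that of the unsubstituted ring (a 1.2-fold lower number from compound 2 to compound 4 (0.08 log units; within the scatter)), which shows that this ring can carry a bromine with no measurable cost in binding. No measurement here explains why methyl and bromo behave so differently on this ring.

The names 4-methylphenyl and 2-bromophenyl differ in both the group and its ring position, so these compounds cannot separate the two effects; 2-methylphenyl and 4-bromophenyl would be needed to do that. As far as these compounds go, it also remains open whether other groups on this ring, such as methoxy, an amine or a carboxylic acid, would stay level with bromo or shift the number as methyl does.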